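The source may report more compounds than this note shows. Statements on the series, on what has been measured and on what is new or still open speak of the compounds shown alone.

Compound 1 `Cc1ccc(-c2ccc(F)cc2)n1-c1ccc(-c2nc3ccc(F)cc3s2)cc1`, compound 2 `COc1cc(-c2ccc(C)n2-c2ccc(-c3nc4ccc(F)cc4s3)cc2)cc(OC)c1OC` and compound 3 `COc1ccc2nc(-c3ccc(-n4c(C)ccc4-c4ccc(F)cc4)cc3)sc2c1` share one core and were tested in a functional assay on MCF7 cells (Homo sapiens) for cytotoxicity, read by MTT assay, with a stated time of 72 h; on this read-out lower numbers stand for stronger inhibition and higher numbers for weaker inhibition. In this assay compound 1 gives 2800 nM, compound 2 gives 2360 nM and compound 3 gives 2800 nM, so the three numbers sit within the usual scatter of one another. The difference between the cores of compound 1 and compound 2 is not broken down here. From compound 1 to compound 3 the change is methoxy in place of fluoro on an aromatic carbon, and it made no change at the digits printed from compound 1 to compound 3 (within the scatter). Compound 4 `COc1ccc2nc(-c3ccc(-n4c(C)ccc4-c4cc(OC)c(OC)c(OC)c4)cc3)sc2c1` is not yet measured; from compound 2 it carries methoxy in place of fluoro on an aromatic carbon, the same change at the same place. Since that earlier step was no change at the digits printed from compound 1 to compound 3 (within the scatter), the expected step is a 1.0-fold higher number from compound 2 to compound 4 (0.01 log units; within the scatter). Compound 4 is therefore estimated at 2400 nM, expected to fall between 1200 nM and 4800 nM.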

Compound 4, half-maximal inhibitory concentration: 1520 nM
Compound 4: middle estimate off by 1.6-fold (0.20 log units), on the high side; the measured number falls inside the stated range.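

In this assay, replacing 6-fluoro-1,3-benzothiazol-2-yl with 6-methoxy-1,3-benzothiazol-2-yl gives a 1.6-fold lower number from compound 2 to compound 4 (0.19 log units; within the scatter). Set beside the earlier step, the swap reads the same on both cores: the same change on two cores in this assay, no change at the digits printed (within the scatter) from compound 1 to compound 3 and a 1.6-fold lower number (0.19 log units; within the scatter) from compound 2 to compound 4, 1.6-fold (0.19 log units) apart, within the scatter of two such steps. Among the compounds shown here, this suggests that, for these two cores, the result of the swap carries over from one to the other, but it does not show that the swap itself helps or harms, as each step lies within the scatter and only two cores are compared.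

The compounds shown leave open whether a different group at this place, such as an amine or a carboxylic acid, would shift the number beyond the scatter. They also leave open whether the swap would read the same on a third core.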